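A Chloroacetamide Swap on the Shared Core

The source may report more compounds than this note shows. Statements on the series, on what has been measured and on what is new or still open speak of the compounds shown alone.

Measured compounds:
Compound 1 `O=C(CCl)Nc1ccc(Cn2nc(-c3ccc(Oc4ccccc4)cc3)cc2CO)cc1` — 400 nM
Compound 2 `C/C=C/C(=O)Nc1cccc(Cn2nc(-c3ccc(Oc4ccccc4)cc3)cc2C(=O)OCC)c1` — 14200 nM
Compound 3 `C=CC(=O)Nc1cccc(Cn2nc(-c3ccc(Oc4ccccc4)cc3)cc2C(=O)OCC)c1` — 8600 nM

In a functional assay on Maver1 cells (Homo sapiens) for inhibition, read by luminescence and CellTiter-Glo, with a stated time of 72 h (on this read-out lower numbers stand for stronger inhibition and higher numbers for weaker inhibition), compound 3 gives 8600 nM, the second highest of the three numbers. Compound 2 gives 14200 nM, and the step of a 1.7-fold lower number from compound 2 to compound 3 (0.22 log units; within the scatter) is the only measured one between single-change neighbours. Compound 1 gives 400 nM, far below compound 3, though the two differ in more than one place.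

Compound 4 `CCOC(=O)c1cc(-c2ccc(Oc3ccccc3)cc2)nn1Cc1ccc(NC(=O)CCl)cc1` differs from compound 3 by 4-(((chloromethyl)carbonyl)amino)phenyl in place of 3-((vinylcarbonyl)amino)phenyl on a saturated chain carbon bound to an aromatic nitrogen. The measured step concerns the vinyl against prop-1-en-1-yl exchange and does not bear on this change. Compound 1 carries the entering group, beside a hydroxymethyl instead of the ethyl ester, and its number lies well below that of compound 3.

A lower number for compound 4 is therefore expected, a 5.7-fold lower number from compound 3 to compound 4 (0.76 log units; beyond the scatter), with an estimate of 1500 nM and a range from 300 nM to 7000 nM.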

Compound 4, half-maximal inhibitory concentration: 400 nM
The estimate for compound 4 lay 3.8-fold (0.57 log units) above the measured number; the range from low to high includes it.
By their numbers in this assay, from the lowest: compounds 1 and 4 (each within the scatter of the next); then compounds 3 and 2 (each within the scatter of the next).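

In this assay the group on the saturated chain carbon bound to an aromatic nitrogen matters greatly: the exchange for 4-(((chloromethyl)carbonyl)amino)phenyl gives a 22-fold lower number from compound 3 to compound 4 (1.33 log units; beyond the scatter) and a 36-fold lower number from compound 2 to compound 4 (1.55 log units; beyond the scatter). By contrast, ethoxycarbonyl in place of hydroxymethyl on an aromatic carbon gives no change at the digits printed from compound 1 to compound 4 (within the scatter), so the number stays put across that exchange with the entering group present. Nothing measured here accounts for the large steps. The entering and leaving groups differ both in the chain on the carbonyl and in the numbering on the phenyl, and the compounds shown do not separate these two differences. They also leave open how a carboxylic acid or a primary amide would behave in place of the ethoxycarbonyl.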